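Trimethoxyphenyl Triazoles: Dichlorophenyl in Place of Aminophenyl

A few compounds are considered here, and "the series" means these few. Any claim that something is new, unique, unknown or untested is made for them only; others in the source may bear on it.

Compound 1 `COc1cc(-n2ncnc2-c2cccc([N+](=O)[O-])c2)cc(OC)c1OC` in a functional assay on HL-60 cells (Homo sapiens) for antiproliferative activity, read by MTT assay, with a stated time of 72 h; a higher number here means a weaker inhibitor, a lower number a stronger inhibitor: > 10000 nM
Compound 2 `COc1ccccc1-c1ncnn1-c1cc(OC)c(OC)c(OC)c1`: > 10000 nM
Compound 3 `COc1cc(-c2ncnn2-c2cccc(N)c2)cc(OC)c1OC`: > 10000 nM

Of the compounds shown here, three built on a shared core have so far been tested in this assay. Compound 1 gives > 10000 nM, which is a limit of the assay and not a number. Compound 2 gives > 10000 nM, again only a limit. Compound 3 gives > 10000 nM, also a limit. Compound 3 therefore stands exactly where the other two stand, at the limit of > 10000 nM in this assay, at which 3 of the 3 values shown sit, and nothing in the numbers separates any of the three. Going by the values given here, no two of the measured compounds differ in only one place, so no measured step is available to guide the next move.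

Compound 4 `COc1cc(-c2ncnn2-c2ccc(Cl)c(Cl)c2)cc(OC)c1OC` has not yet been measured. It differs from compound 3 in one place: 3,4-dichlorophenyl in place of 3-aminophenyl on an aromatic nitrogen. Among the compounds with values here, with no measured step to lean on, and with compound 3 resting at the limit of > 10000 nM in this assay, at which 3 of the 3 values shown sit, the step of an at least 1.2-fold lower number from compound 3 to compound 4 (0.09 log units; that floor lies within the scatter) is expected to be modest, a possible gain rather than a loss, but not one that can be foreseen with confidence. Compound 4 is therefore estimated at 8000 nM, within a range from 1500 nM to 30000 nM, and it is expected that the assay may once more report only a limit for compound 4.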

Compound 4, half-maximal inhibitory concentration: > 10000 nM
Compound 4 ended at the assay's limit; the forecaster's own chance of this, stated with the estimate: 60%; middle value at least 1.2-fold (0.09 log units) from the limit.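

In this assay compound 4 gives > 10000 nM, which is a limit of the assay and not a number. Compound 3 also rests at a limit, so the step between compound 3 and compound 4 cannot be read. The compounds shown all stand at the same place: the limit of > 10000 nM in this assay, at which 4 of the 4 values shown sit.

The compounds shown leave open whether any change on the shared core brings a readable value in this assay.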